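Adding one fluoro group to compound 2

The source may hold more compounds than are shown below. What is called first, only, known or untested is meant among the compounds shown, and "the series" means these compounds.

In an ADME assay on HUVEC cells (Homo sapiens) for inhibition, read by CCK-8 assay, with a stated time of 24 h, in the presence of a further agent that is not named here (a lower number here means a stronger inhibitor, a higher number a weaker inhibitor), compound 1 `Cc1ccccc1-n1cc(-c2ccc(/C=C3\C(=O)Nc4ccccc43)cc2)nn1` gives 14700 nM and compound 2 `Cc1cccc(-n2cc(-c3ccc(/C=C4\C(=O)Nc5ccccc54)cc3)nn2)c1` gives 13700 nM. On these two numbers, compound 2 stands level with compound 1, within the usual scatter of repeated measurements. Compound 3 `Cc1cccc(-n2cc(-c3ccc(/C=C4\C(=O)Nc5ccc(F)cc54)cc3)nn2)c1` matches compound 2 except for one change: fluoro in place of hydrogen on an aromatic carbon. Among the compounds with values here, the only measured step, a 1.1-fold lower number from compound 1 to compound 2 (0.03 log units; within the scatter), lies within the scatter and concerns a different part of the molecule, so it bears only loosely on this change. Within the data shown here, no measured pair shows what a fluoro group does here. A step beyond the scatter is therefore not expected in this assay, though the uncertainty is wide. The estimated change is a 1.1-fold lower number from compound 2 to compound 3 (0.06 log units; within the scatter). Compound 3 is expected to give about 12000 nM, with an estimated range of 5000 nM to 25000 nM.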

Compound 3, half-maximal inhibitory concentration: 9880 nM
The estimate for compound 3 lay 1.2-fold (0.08 log units) above the measured number; measured number inside the range.
By their numbers in this assay, from the lowest: compounds 3, 2 and 1 (each within the scatter of the next).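

Within the data shown here, the step of a 1.4-fold lower number from compound 2 to compound 3 (0.14 log units; within the scatter) is the first measured reading for a change on this part of the molecule, in this assay. It lies within the scatter, so at this place, meta to one fused ring and para to another, fluoro in place of hydrogen does not set compound 3 apart from compound 2. No measurement at hand explains the result.

As far as these compounds go, it remains open whether another group at the same carbon, such as chloro, methoxy, an amine or a carboxylic acid, would shift the number beyond the scatter. From the compounds shown here alone, it also remains open whether fluoro on a different carbon of this ring, or on the 3-methylphenyl ring, would do so.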